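This account rests on a few compounds, and the source may have more. Where it says the series, first, only, none or still open, it means among the compounds named here.

Measured so far:
compound 1 `O=C(O)CCc1ccc(OCc2cccc(C(F)(F)F)c2)cc1`, 83.2 nM in a functional assay on 1321-N1 cells for agonist activity at Free fatty acid receptor 1 (Homo sapiens), read by calcium flux; a higher number here means that more compound is needed for the effect, a lower number that less compound is needed
compound 2 `O=C(O)CCc1ccc(OCc2cccc(-c3ccccc3)c2)cc1`, 135 nM in this assay

In this assay compound 2 stands alongside compound 1: the step of a 1.6-fold higher number from compound 1 to compound 2 (0.21 log units; within the scatter) lies within the scatter, so the two numbers are not separable. Compound 3 `COc1ccccc1-c1cccc(COc2ccc(CCC(=O)O)cc2)c1` carries methoxy in place of hydrogen on an aromatic carbon. Among the compounds with values here, no measured step adds a methoxy; the single known step, trifluoromethyl to phenyl, bears only loosely on it and was small. The change is therefore expected to leave the number in this assay about where compound 2 sits, with the step of no change at the digits printed from compound 2 to compound 3 (within the scatter) estimated and no direction claimed. Compound 3 is estimated at 135 nM, range 45 nM to 400 nM.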

Compound 3, half-maximal effective concentration: 120 nM
Beside the measured number, compound 3's estimate is 1.1-fold (0.05 log units) above it; the measured number falls inside the stated range.
By their numbers in this assay, from the lowest: compounds 1, 3 and 2 (each within the scatter of the next).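

In this assay, methoxy in place of hydrogen on an aromatic carbon ortho to a large group gives a 1.1-fold lower number from compound 2 to compound 3 (0.05 log units; within the scatter) and so leaves the two numbers not separable. The wider change, 2-methoxyphenyl in place of trifluoromethyl, gives a 1.4-fold higher number from compound 1 to compound 3 (0.16 log units; within the scatter) and is likewise not separable, so this position has so far accepted all three groups without a step beyond the scatter. No supporting data bear on this result.

Open, from the compounds shown here alone, is whether an amine, a carboxylic acid or a longer chain such as butoxy at this carbon would separate from compound 2. Also open, going by these compounds, is whether methoxy on another carbon of that ring would read the same.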